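Ethyl removal from the bicyclic core: expected cytotoxicity

This account rests on a few compounds, and the source may have more. Where it says the series, first, only, none or still open, it means among the compounds named here.

Compound 1 `CCc1ccc2[nH]c(=O)c(CN(Cc3ccc(C(C)(C)C)cc3)[C@H](CO)c3ccccc3)cc2c1` in a toxicity assay on MDCK cells (Canis lupus familiaris) for cytotoxicity, read by crystal violet staining, with a stated time of 48 h (on this read-out lower numbers stand for higher toxicity in this test and higher numbers for lower toxicity in this test), gives a limit of > 10000 nM rather than a number.
Compound 2 `CCc1ccc2[nH]c(=O)c(CN(Cc3ccc(C(C)(C)C)cc3)[C@@H](C)c3ccc(F)cc3)cc2c1` in this assay gives a limit of > 5000 nM, not a number.
Compound 3 `CCc1ccc2[nH]c(=O)c(CN(Cc3ccc(C(C)(C)C)cc3)[C@@H](C)c3ccc(OC)cc3)cc2c1` in this assay gives a limit of > 5000 nM, again only a limit.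

Compound 3 thus stands at a limit of this assay, as do the two other measured compounds; none of the three has a read number. The steps among them cannot be sized: a step that the two limits leave unreadable from compound 1 to compound 2, a step that the two limits leave unreadable from compound 1 to compound 3 and a step that the two limits leave unreadable from compound 2 to compound 3 are all left unreadable by the limits.

Compound 4 `COc1ccc([C@H](C)N(Cc2ccc(C(C)(C)C)cc2)Cc2cc3ccccc3[nH]c2=O)cc1` differs from compound 3 by hydrogen in place of ethyl on an aromatic carbon. Within the data shown here, none of the measured steps touches this position, and all of them are unreadable, so no direction or size can be drawn from them. In this assay compound 4 is therefore expected to sit near the same limit, with a step that the limit leaves unreadable from compound 3 to compound 4 at most a guess, and its estimated value is 8000 nM, in a range from 4000 nM to 20000 nM.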

Compound 4, half-maximal cytotoxic concentration: 1800 nM
Estimate against measurement, compound 4: 4.4-fold (0.65 log units) above; the whole stated range lies above it.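

Hydrogen in place of ethyl on an aromatic carbon of the shared core gives, in this assay, an at least 2.7-fold lower number from compound 3 to compound 4 (0.44 log units; beyond the scatter), so this position bears on the read-out, with the change toward higher toxicity in this test. Among the four compounds, only compound 4 has a read number, whereas the steps among compound 1, compound 2 and compound 3 cannot be read and gave no direction for any change. The step has only a lower bound because compound 3 stands at a limit: the limit of > 5000 nM in this assay, at which 2 of the 4 values shown sit.

As far as these compounds go, whether the loss of ethyl specifically matters, or whether a methyl group, a longer chain such as propyl or a carboxylic acid at this carbon would give a different number, remains open. From the compounds shown here alone, it is also open whether the same change gives a similar step with the 2-hydroxy-1-phenylethyl group of compound 1 or the 1-(4-fluorophenyl)ethyl group of compound 2 on the amine nitrogen.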